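The compounds below may be only part of what the source reports. "The series", "measured", "known", "first", "only" and "open" are said of these compounds alone.

Measured in a functional assay on SK-MEL-5 cells (Homo sapiens) for antiproliferative activity; on this read-out higher numbers stand for weaker inhibition of growth and lower numbers for stronger inhibition of growth:
Compound 1 `COCCCCCCCCCCCCCCC/C=C1\CC(CO)(COC(=O)C(C)(C)C)OC1=O`: 1.75 ug/mL
Compound 2 `CCCCCCCCC(O)CCCCCC/C=C1\CC(CO)(COC(=O)C(C)(C)C)OC1=O`: > 10 ug/mL

The value of compound 2 is > 10 ug/mL, which is a limit of the assay and not a number. Among the measured compounds shown here, it is the only value of the two at that limit (the limit of > 10 ug/mL in this assay, at which 1 of the 2 values shown sits). Compound 3 `CCCCCOCCCCCCC/C=C1\CC(CO)(COC(=O)C(C)(C)C)OC1=O` has not yet been measured. It carries (pentyloxy)methyl in place of 1-hydroxynonyl, on a saturated chain carbon, six bonds along the chain from a double-bonded chain carbon ((pentyloxy)methyl in place of 1-hydroxynonyl on a saturated chain carbon, six bonds along the chain from a double-bonded chain carbon). For the measured compounds named here, the one measured step that bears on this change is an at least 5.7-fold higher number from compound 1 to compound 2 (0.75 log units; beyond the scatter), which replaced 9-methoxynonyl with 1-hydroxynonyl. Going by compound 1 at 1.75 ug/mL, which also has an ether in its chain, a lower number is expected for compound 3. The expected step in this assay is an at least 3.3-fold lower number from compound 2 to compound 3 (0.52 log units; beyond the scatter), towards stronger inhibition of growth. For compound 3 the estimate is 3 ug/mL, with an expected range of 1.2 ug/mL to 8 ug/mL.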

Compound 3, concentration for 50% growth inhibition: 2.99 ug/mL
Compound 3: middle estimate off by 1.0-fold (0.00 log units), on the high side; low and high end bracket the measured number.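

In this assay, the exchange of 1-hydroxynonyl for (pentyloxy)methyl, on a saturated chain carbon, six bonds along the chain from a double-bonded chain carbon, gave an at least 3.3-fold lower number from compound 2 to compound 3 (0.52 log units; beyond the scatter), so a second chain with an ether oxygen now stands apart from the hydroxyl chain. Going by these compounds, the size of that step stays open at one end, as compound 2 gives > 10 ug/mL, which is a limit of the assay and not a number: the limit of > 10 ug/mL in this assay, at which 1 of the 3 values shown sits. The ether oxygen also sits at a different place in each ether chain, and that shift, with pentyloxy in place of 8-methoxyoctyl, gave a 1.7-fold higher number from compound 1 to compound 3 (0.23 log units; within the scatter).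

The two chains that differ at this position also differ in length, so the hydroxyl and the chain length cannot be told apart here. On these data alone, how an amine or a carboxylic acid would fare at this place, or a longer chain carrying the ether oxygen, remains open.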